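The source may report more compounds than this note shows. Statements on the series, on what has been measured and on what is new or still open speak of the compounds shown alone.

Measured in an in vitro ADME assay on microsomes (Homo sapiens) for metabolic stability; a higher number here means that the compound lasts longer, a lower number that the compound disappears faster:
- compound 1 `CCc1nc(NC(CC)CC)c(OC)nc1-c1ccc(OC(F)F)cc1Cl`: 2 h
- compound 2 `CCc1nc(-c2ccc(OC)cc2OC(F)(F)F)c(CC)nc1NC(CC)CC`: 0.267 h
- compound 3 `CCc1nc(-c2ccc(Cl)cc2Cl)c(CC)nc1NC(C1CC1)C1CC1`: 0.183 h

Compound 3 lies within the scatter of compound 2, while compound 1 lies beyond the scatter above it. The next compound, compound 4 `CCc1nc(-c2ccc(Cl)cc2Cl)c(CC)nc1CC(CC)CC`, carries 2-ethylbutyl in place of (dicyclopropylmethyl)amino on an aromatic carbon. For the measured compounds named here, no measured pair shows this change, so the expectation starts from compound 3 at 0.183 h, and no step beyond the scatter is expected in this assay. The estimate amounts to an expected 1.1-fold higher number from compound 3 to compound 4 (0.04 log units; within the scatter). For compound 4 the expected half-life is 0.2 h, within an estimated range of 0.07 h to 0.55 h.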

Compound 4, half-life: 0.217 h
Estimate against measurement, compound 4: 1.1-fold (0.04 log units) below; low and high end bracket the measured number.
By their numbers in this assay, from the lowest: compounds 3, 4 and 2 (each within the scatter of the next); then compound 1.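

In this assay, for the compounds shown here, this is the first comparison that differs in one place: a 1.2-fold higher number from compound 3 to compound 4 (0.07 log units; within the scatter). With 2-ethylbutyl in place of (dicyclopropylmethyl)amino on this aromatic carbon, both cyclopropane rings and the hydrogen-bond donor and acceptor counted for that group are gone, yet the two half-lives lie within the usual scatter of each other. Nothing available gives a reason for this result.

As far as these compounds go, it remains open whether a morpholine or a carboxylic acid at this position would give a similar half-life. From the compounds shown here alone, it is also open whether the same exchange would read alike with another aryl group on the shared core.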